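The source may hold more compounds than are shown below. What is called first, only, known or untested is meant among the compounds shown, and "the series" means these compounds.

Measured compounds:
compound 1 `CN1CCC(c2c[nH]c3ccc(NC(=O)c4ccc(C#N)cc4)nc23)CC1` — 7.2 nM
compound 2 `CN1CCC(c2c[nH]c3ccc(NC(=O)c4cccs4)nc23)CC1` — 7.1 nM

In an assay for binding affinity to 5-hydroxytryptamine receptor 1F (Homo sapiens), read by radioligand binding (on this read-out higher numbers stand for weaker inhibition and lower numbers for stronger inhibition), compound 2 gives 7.1 nM, the lower of the two numbers, although the step of a 1.0-fold lower number from compound 1 to compound 2 (0.01 log units; within the scatter) lies within the scatter. Compound 3 `CN1CCC(c2c[nH]c3ccc(NC(=O)c4ccncc4)nc23)CC1` differs from compound 2 in one place: pyridin-4-yl in place of thiophen-2-yl on a carbonyl carbon. Among the measured compounds shown here, the only measured step bearing on this, swapping one aromatic ring for another on the same carbonyl carbon, is a 1.0-fold lower number from compound 1 to compound 2 (0.01 log units; within the scatter), so a further ring swap is expected to give no step beyond the scatter; the expected step is a 1.1-fold higher number from compound 2 to compound 3 (0.05 log units; within the scatter). Compound 3 is therefore estimated at 8 nM, within 3 nM to 22 nM.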

Compound 3, inhibition constant: 8.4 nM
Compound 3: the middle estimate sits 1.1-fold (0.02 log units) below what was measured, within the range that was stated.
By their numbers in this assay, from the lowest: compounds 2, 1 and 3 (each within the scatter of the next).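

In this assay pyridin-4-yl on the carbonyl carbon gives a 1.2-fold higher number from compound 2 to compound 3 (0.07 log units; within the scatter) and a 1.2-fold higher number from compound 1 to compound 3 (0.07 log units; within the scatter) and so both steps stay within the scatter. Three different aromatic rings, thiophen-2-yl, 4-cyanophenyl and now pyridin-4-yl, therefore cannot be told apart at this position. Nothing available explains this result.

As far as these compounds go, whether the same holds without an aromatic ring on this carbonyl carbon stays open, for example with a cyclohexyl ring or a straight alkyl chain. An amine or a carboxylic acid on the ring is also untested among the compounds shown.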